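A few compounds are considered here, and "the series" means these few. Any claim that something is new, unique, unknown or untested is made for them only; others in the source may bear on it.

In an ADME assay on L02 cells (Homo sapiens) for cytotoxicity, read by MTT assay, with a stated time of 24 h (on this read-out higher numbers stand for weaker inhibition and lower numbers for stronger inhibition), compound 3 `O=C1/C(=C/c2cccnc2)CNC/C1=C\c1ccccc1C(F)(F)F` gives 11300 nM, the same number as compound 2 `O=C1/C(=C/c2cccnc2)CN(S(=O)(=O)c2ccc(C(F)(F)F)cc2)C/C1=C\c1ccccc1F` at 11300 nM. Compound 1 `O=C1/C(=C/c2cccnc2)CNC/C1=C\c1ccccc1F` gives 15900 nM, which is within the scatter of compound 3. The next compound, compound 4 `O=C1/C(=C/c2cccnc2)CN(S(=O)(=O)c2ccc(Br)cc2)C/C1=C\c1ccccc1C(F)(F)F`, differs from compound 3 by (4-bromophenyl)sulfonyl in place of hydrogen on an amine nitrogen in a ring. Going by the values given here, the only measured step is a 1.4-fold lower number from compound 1 to compound 3 (0.15 log units; within the scatter), and it concerns an aromatic carbon, so no measured step isolates a change on that nitrogen. The closest guide is compound 2 at 11300 nM, which also carries a sulfonyl group on that nitrogen and matches compound 3 at the digits shown. In this assay no change beyond the scatter is therefore expected, and the expected step is a 1.0-fold lower number from compound 3 to compound 4 (0.01 log units; within the scatter). The estimated value for compound 4 is 11000 nM, with an expected range of 5500 nM to 22000 nM.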

Compound 4, half-maximal inhibitory concentration: 13300 nM
Compound 4: the middle estimate sits 1.2-fold (0.08 log units) below what was measured; measured number inside the range.
By their numbers in this assay, from the lowest: compounds 2, 3, 4 and 1 (each within the scatter of the next).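

In this assay, going by these compounds alone, the step of a 1.2-fold higher number from compound 3 to compound 4 (0.07 log units; within the scatter) is the first measured step on the amine nitrogen in the ring, as the only earlier step concerned an aromatic carbon. It shows that, for this pair, replacing the hydrogen on that nitrogen with (4-bromophenyl)sulfonyl, which brings in a six-membered aromatic ring and removes no heavy atom, keeps the read-out within the usual scatter. No measurement on hand accounts for this result.

Going by these compounds, whether this tolerance extends beyond sulfonyl groups remains open, for example to an acetyl group, a longer alkyl chain or a chain ending in a carboxylic acid on the same nitrogen. On these data alone, it is also open whether a primary amine or a methoxy group in place of the bromine on the phenyl ring would stay within the scatter.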